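The compounds below may be only part of what the source reports. "The series", "measured", "known", "first", "only" and "open" are said of these compounds alone.

Compound 1 `COc1cc(C(=O)c2cn(-c3cccc(C)c3)cc2-c2ccccc2Cl)cc(OC)c1OC`: 420 nM
Compound 2 `COc1cc(C(=O)c2cn(-c3cccc(C)c3)cc2-c2cccc([N+](=O)[O-])c2)cc(OC)c1OC`: 880 nM
Compound 3 `COc1cc(C(=O)c2cn(-c3cccc(C)c3)cc2-c2ccc([N+](=O)[O-])cc2)cc(OC)c1OC`: 780 nM

All three values come from a functional assay on MCF7 cells (Homo sapiens) for cytotoxicity, read by MTT assay, with a stated time of 96 h; a higher number here means a weaker inhibitor, a lower number a stronger inhibitor. Compound 3 cannot be separated from either of the others, as a 1.1-fold lower number from compound 2 to compound 3 (0.05 log units; within the scatter) and a 1.9-fold higher number from compound 1 to compound 3 (0.27 log units; within the scatter) both stay inside the scatter. Compound 4 `COc1cc(C(=O)c2cn(-c3cccc(C)c3)cc2-c2ccc(N)cc2)cc(OC)c1OC` differs from compound 3 by amino in place of nitro on an aromatic carbon, para to a large group: amino in place of nitro on an aromatic carbon.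

Among the measured compounds shown here, no measured step makes this exchange, so the evidence is indirect. Moving the nitro gave a 1.1-fold lower number from compound 2 to compound 3 (0.05 log units; within the scatter), and the largest step at this aryl group, a 2.1-fold higher number from compound 1 to compound 2 (0.32 log units; beyond the scatter), is only modest. Changes here have therefore been small so far. For the measured compounds named here, the one compound without a nitro, compound 1, gives 420 nM, which points weakly towards a lower number in this assay. The expected change is modest, a 1.7-fold lower number from compound 3 to compound 4 (0.24 log units; within the scatter), and it may not clear the scatter. For compound 4 the estimated value is 450 nM, with an expected range from 120 nM to 1300 nM.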

Compound 4, half-maximal inhibitory concentration: 18 nM
Beside the measured number, compound 4's estimate is 25-fold (1.40 log units) above it, and the stated range ends above it.
By their numbers in this assay, from the lowest: compound 4; then compounds 1, 3 and 2 (each within the scatter of the next, the first and the last beyond it).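

Among the earlier compounds, changes at this aryl group moved the number little, but the exchange of nitro for amino gives a 43-fold lower number from compound 3 to compound 4 (1.64 log units; beyond the scatter) in this assay, so this para position can strongly affect the result. Having no nitro is not enough to explain the gap, since compound 1 also lacks one and the change to the 4-aminophenyl group still gives a 23-fold lower number from compound 1 to compound 4 (1.37 log units; beyond the scatter), while the 3-nitrophenyl comparison gives a 49-fold lower number from compound 2 to compound 4 (1.69 log units; beyond the scatter) and compound 4 stands apart from all three. Nothing available explains why the amino group has this effect.

The compounds shown leave open whether the amino group itself is required, as a hydroxyl or a dimethylamino group in the same place would test. They also leave open whether an acetamide there would keep any of this result.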